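The source may report more compounds than this note shows. Statements on the series, on what has been measured and on what is new or still open speak of the compounds shown alone.

Going by the values given here, in a functional assay on MCF7 cells (Homo sapiens) for cytotoxicity, read by MTT assay, with a stated time of 72 h (a lower number here means a stronger inhibitor, a higher number a weaker inhibitor), compound 2 (`O=C(N/N=C/c1ccc(F)cc1Cl)Nc1cc2c(Nc3ccc(F)c(Cl)c3)ncnc2cc1O[C@H]1CCOC1`) gives 32200 nM, the only number available so far, while compound 1 (`O=C(N/N=C/c1ccc([N+](=O)[O-])cc1)Nc1cc2c(Nc3ccc(F)c(Cl)c3)ncnc2cc1O[C@H]1CCOC1`) is reported as "not active" (no number reported), with no number. Compound 3 (`COc1ccc(/C=N/NC(=O)Nc2cc3c(Nc4ccc(F)c(Cl)c4)ncnc3cc2O[C@H]2CCOC2)cc1`) keeps the shared core but exchanges one group: 4-methoxyphenyl in place of 2-chloro-4-fluorophenyl on a carbon with a double bond to nitrogen. Among the compounds with values here, no measured step shows what such an exchange does in this assay, so no shift beyond the usual scatter is expected, in either direction. The estimated change, a 1.1-fold higher number from compound 2 to compound 3 (0.04 log units; within the scatter), is therefore small. For compound 3 the expected value is 35000 nM, with an estimated range from 12000 nM to 100000 nM.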

Compound 3, half-maximal inhibitory concentration: 27300 nM
Beside the measured number, compound 3's estimate is 1.3-fold (0.11 log units) above it, within the range that was stated.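

Going by these compounds alone, the exchange of 2-chloro-4-fluorophenyl for 4-methoxyphenyl on a carbon with a double bond to nitrogen gives the first readable step at this position: in this assay, the result is a 1.2-fold lower number from compound 2 to compound 3 (0.07 log units; within the scatter). This assay therefore does not separate these two groups. No supporting measurement bears on this result.

Steps involving compound 1 cannot be read, as it has no number. On these data alone, whether an amine or a carboxylic acid on the phenyl ring at this position would move the value beyond the scatter remains open.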